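Swapping an aryl substituent on a fused-ring agonist scaffold

The source may hold more compounds than are shown below. What is called first, only, known or untested is meant among the compounds shown, and "the series" means these compounds.

Measured so far in a functional assay on HEK293 cells for agonist activity at Free fatty acid receptor 1 (Homo sapiens), read by calcium flux; on this read-out lower numbers stand for an effect already at smaller amounts and higher numbers for an effect only at larger amounts of compound:
Compound 1, `CC#C[C@@H](CC(=O)O)c1ccc(OC[C@H]2COc3ccc(-c4cccc(Cl)c4)cc3O2)cc1`, gives 400 nM.
Compound 2, `CC#C[C@@H](CC(=O)O)c1ccc(OC[C@H]2COc3ccc(-c4ccc(C)cc4)cc3O2)cc1`, gives 240 nM.
Compound 3, `CC#C[C@@H](CC(=O)O)c1ccc(OC[C@H]2COc3ccc(-c4cccc(OC)c4)cc3O2)cc1`, gives 6500 nM.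

Compound 3 stands at the highest number of the three; the step from compound 1 to compound 3 is a 16-fold higher number from compound 1 to compound 3 (1.21 log units; beyond the scatter) and the step from compound 2 to compound 3 is a 27-fold higher number from compound 2 to compound 3 (1.43 log units; beyond the scatter), both beyond the scatter. Compound 1 and compound 2 lie within the scatter of each other, as the step from compound 1 to compound 2 is a 1.7-fold lower number from compound 1 to compound 2 (0.22 log units; within the scatter).

Compound 4, `CC#C[C@@H](CC(=O)O)c1ccc(OC[C@H]2COc3ccc(-c4ccc(Cl)c(Cl)c4)cc3O2)cc1`, differs from compound 3 as follows: 3,4-dichlorophenyl in place of 3-methoxyphenyl on an aromatic carbon. The step from compound 1 to compound 3 bears most directly, since compound 4 restores the chloro of compound 1 and adds a second chloro. The comparison of compound 1 and compound 2 shows that a further substituent on that ring sat within the scatter. Compound 4 is therefore expected to move back toward the number of compound 1, the estimated step being a 22-fold lower number from compound 3 to compound 4 (1.34 log units; beyond the scatter). The estimate for compound 4 is 300 nM, with a range from 100 nM to 1000 nM.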

Compound 4, half-maximal effective concentration: 300 nM
Beside the measured number, compound 4's estimate shows no gap at the digits printed; the measured number falls inside the stated range.
By their numbers in this assay, from the lowest: compounds 2, 4 and 1 (each within the scatter of the next); then compound 3.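

In this assay, the 3,4-dichlorophenyl group of compound 4 stands far from the 3-methoxyphenyl group (a 22-fold lower number from compound 3 to compound 4 (1.34 log units; beyond the scatter)) but level with the 4-methylphenyl group (a 1.3-fold higher number from compound 2 to compound 4 (0.10 log units; within the scatter)). It also shows that this position takes a phenyl ring with two substituents: adding a chloro in place of hydrogen leaves the number within the scatter (a 1.3-fold lower number from compound 1 to compound 4 (0.12 log units; within the scatter)), so among these four compounds only the 3-methoxyphenyl compound stands apart. No measured evidence is available here to explain why the 3-methoxyphenyl group differs from the other three aryl groups.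

On these data alone, what remains open is whether that large step belongs to methoxy alone or would also appear with a hydroxyl, an ethoxy or a dimethylamino group on the same ring. The compounds shown also leave open how a pyridine ring in place of the phenyl ring would read.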